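Amide aryl change in the flavonol series

A few compounds are considered here, and "the series" means these few. Any claim that something is new, unique, unknown or untested is made for them only; others in the source may bear on it.

Within the data shown here, compound 2 `COc1ccc(C(=O)Nc2cccc(-c3oc4cc(-c5ccc(F)cc5)ccc4c(=O)c3O)c2)c(F)c1` gives 24500 nM in a functional assay on HCC1937 cells (Homo sapiens) for antiproliferative activity, read by CCK-8 assay, with a stated time of 72 h (a lower number here means a stronger inhibitor, a higher number a weaker inhibitor), the higher of the two numbers so far; compound 1 `O=C(Nc1cccc(-c2oc3cc(-c4ccc(F)cc4)ccc3c(=O)c2O)c1)c1ccc(Br)cc1` gives 8630 nM. Among the measured compounds shown here, the one measured step that bears on the new change is a 2.8-fold higher number from compound 1 to compound 2 (0.45 log units; beyond the scatter). Compound 3 `N#Cc1ccc(C(=O)Nc2cccc(-c3oc4cc(-c5ccc(F)cc5)ccc4c(=O)c3O)c2)cc1` carries 4-cyanophenyl in place of 2-fluoro-4-methoxyphenyl on a carbonyl carbon. Like the 4-bronophenyl of compound 1, the 4-cyanophenyl carries a single substituent, so a return toward the number of compound 1 is expected, with a modest step of a 2.5-fold lower number from compound 2 to compound 3 (0.39 log units; beyond the scatter). Compound 3 is estimated at 10000 nM in this assay, within a range of 4000 nM to 25000 nM.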

Compound 3, half-maximal inhibitory concentration: 2990 nM
Compound 3: middle estimate off by 3.3-fold (0.52 log units), on the high side; measured number outside the range, below it.
By their numbers in this assay, from the lowest: compound 3; then compound 1; then compound 2.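

The aryl group on this carbonyl carbon moves the number further than the first pair suggested, with an 8.2-fold lower number from compound 2 to compound 3 (0.91 log units; beyond the scatter) and compound 3 the strongest of the three. The further change of cyano in place of bromo gives a 2.9-fold lower number from compound 1 to compound 3 (0.46 log units; beyond the scatter) so a single substituent on the ring does not by itself set the number. Nothing available explains these shifts.

As far as these compounds go, it remains open whether the fluoro or the methoxy of the 2-fluoro-4-methoxyphenyl accounts for the higher number of compound 2. From the compounds shown here alone, how an amine or a carboxylic acid on the same ring would compare also remains open.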